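Triazene series on Vero cells: second chloro entering

A few compounds are considered here, and "the series" means these few. Any claim that something is new, unique, unknown or untested is made for them only; others in the source may bear on it.

Measured so far in an ADME assay on Vero cells (Chlorocebus sabaeus) for cytotoxicity, read by crystal violet staining; on this read-out higher numbers stand for lower toxicity in this test and lower numbers for higher toxicity in this test:
compound 1 `c1ccc(/N=N/N2CCCC2)cc1` gives > 100000 nM, a limit of the assay.
compound 2 `COc1ccc(/N=N/N2CCCC2)cc1` gives 90000 nM.
compound 3 `Clc1ccc(/N=N/N2CCCC2)cc1` gives > 100000 nM, a limit of the assay.

Compound 3 therefore stands only at a limit, not at a number, and it shares that position with compound 1 (the limit of > 100000 nM in this assay, at which 2 of the 3 values shown sit). The step that the two limits leave unreadable from compound 1 to compound 3 cannot be read, and an at least 1.1-fold higher number from compound 2 to compound 3 (0.04 log units; that floor lies within the scatter) is too small to stand out from the scatter. Compound 4 `Clc1ccc(/N=N/N2CCCC2)cc1Cl` differs from compound 3 by chloro in place of hydrogen on an aromatic carbon. The one earlier chloro entry gave nothing readable, so no step beyond the scatter is expected in this assay, and compound 4 is estimated at 100000 nM (range 50000 nM to 200000 nM), an expected step of a number no higher from compound 3 to compound 4 (the limit leaves the size open).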

Compound 4, half-maximal cytotoxic concentration: 58000 nM
Beside the measured number, compound 4's estimate is 1.7-fold (0.24 log units) above it; measured number inside the range.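

In this assay, the second chloro, ortho to a chloro group, brings the chloro pair down from a limit to a readable number, which the first chloro entry did not do: an at least 1.7-fold lower number from compound 3 to compound 4 (0.23 log units; that floor lies within the scatter). This floor does not separate the change from the scatter, so no real shift can be claimed. Compound 3 is known only as a limit, and because of that the true size of the step stays open: the limit of > 100000 nM in this assay, at which 2 of the 4 values shown sit.

From the compounds shown here alone, whether an amine or a carboxylic acid at this place would read differently remains open. So does whether this place carries the same reading with a chloro there alone.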